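Phenyl to methyl on a two-carbon chain: a repeated swap

This account rests on a few compounds, and the source may have more. Where it says the series, first, only, none or still open, it means among the compounds named here.

Three compounds share a fused bicyclic core carrying a benzamide-type nitrogen substituent, and each was tested in a functional assay on HT-29 cells (Homo sapiens) for cytotoxicity, read by sulforhodamine B assay, with a stated time of 2 days, tested at 100 uM; on this read-out lower numbers stand for less inhibition and higher numbers for more inhibition at the one concentration tested (going by the name of the read-out). Compound 2 `O=C(Nn1c(-c2cccc([N+](=O)[O-])c2)nc2c(CCc3ccccc3)n[nH]c2c1=O)c1ccccc1` gives 89.7% in this assay. Compound 3 `O=C(Nn1c(CCc2ccccc2)nc2c(-c3ccc(Cl)cc3)n[nH]c2c1=O)c1ccccc1` gives 86.5% in this assay, a figure within the scatter of that of compound 2; the difference between the two cores is not broken down here. Compound 1 `CCCc1n[nH]c2c(=O)n(NC(=O)c3ccccc3)c(-c3cccc([N+](=O)[O-])c3)nc12` gives 18.7% in this assay. Compound 1 is derived from compound 2 by the change (methyl in place of phenyl on a saturated chain carbon, two bonds along the chain from an aromatic carbon), and this change made the step of a number 71 percentage points lower from compound 2 to compound 1 (beyond the scatter).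

Compound 4 `CCCc1nc2c(-c3ccc(Cl)cc3)n[nH]c2c(=O)n1NC(=O)c1ccccc1` has not yet been measured in this assay. It is derived from compound 3 by methyl in place of phenyl on a saturated chain carbon, two bonds along the chain from an aromatic carbon, which is the same change, at the same place, as that from compound 2 to compound 1. Because the earlier step of a number 71 percentage points lower from compound 2 to compound 1 (beyond the scatter) was large, a step of similar size is expected here, a number 64.5 percentage points lower from compound 3 to compound 4 (beyond the scatter), though it rests on a single prior example. Compound 4 is therefore estimated to give 22% in this assay, with a likely range from 5% to 50%.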

Compound 4, a percentage reported as inhibition, at one concentration (the size of the read-out at that concentration, not a potency): 91.1%
Compound 4: middle estimate off by 69.1 percentage points, on the low side; measured number above the stated range.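

In this assay, the replacement of phenyl by methyl did not carry from one core to the other: the earlier large fall did not recur, and the new step was a number 4.6 percentage points higher from compound 3 to compound 4 (within the scatter). The two steps disagree, so the result of this change depends on the core that carries it: the same change on two cores in this assay, a number 71 percentage points lower (beyond the scatter) from compound 2 to compound 1 and a number 4.6 percentage points higher (within the scatter) from compound 3 to compound 4, 75.6 percentage points apart, beyond the scatter of two such steps This does not show which feature of the cores sets the outcome, since the two pairs differ in more than one place, the nitrophenyl group of the first pair being one such difference, and a single pair on each core supports no general rule; the read-out at one concentration also says nothing about potency.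

Still open, from the compounds shown here alone, is whether other aryl groups on the shared core would follow the pair of compound 2 and compound 1 or that of compound 3 and compound 4. Going by these compounds, it is equally open how a longer chain, an amine or a carboxylic acid at the end of the chain would behave on either core.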